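A few compounds are considered here, and "the series" means these few. Any claim that something is new, unique, unknown or untested is made for them only; others in the source may bear on it.

For the measured compounds named here, only two compounds have been tested so far in an ADME assay on HeLa cells (Homo sapiens) for cytotoxicity, read by MTT assay, with a stated time of 2 days; on this read-out higher numbers stand for lower toxicity in this test and lower numbers for higher toxicity in this test. Compound 1 (`CCOC(=O)c1sc2cc(Oc3ccnc(C(=O)NC)c3)ccc2c1C`) reads > 100000 nM, which is a limit of the assay and not a number. Going by the values given here, compound 2 (`CNC(=O)c1cc(Oc2ccc3cc(C(=O)OC)sc3c2)ccn1`) gives 68300 nM, the only true number available, so there is no other measured value to rank it against. Compound 3 (`CNC(=O)c1cc(Oc2ccc3c(C)c(C(=O)OC)sc3c2)ccn1`) comes from compound 2 by a single change: methyl in place of hydrogen on an aromatic carbon. Among the compounds with values here, no measured step shows what this change does in this assay, so the expectation is modest: little or no movement beyond the usual scatter, with a slight lean toward higher numbers. It rests on compound 2 giving 68300 nM, which already indicates low toxicity in this test. The expected change is a 1.2-fold higher number from compound 2 to compound 3 (0.09 log units; within the scatter). Compound 3 is estimated at 85000 nM, with an expected range of 40000 nM to 180000 nM.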

Compound 3, half-maximal cytotoxic concentration: 15700 nM
The estimate for compound 3 lay 5.4-fold (0.73 log units) above the measured number; the measured number lies below the stated range.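

In this assay, methyl on this aromatic carbon of the five-membered ring, next to the ring atom that bears the methoxycarbonyl group, is not a silent change: it gives a 4.4-fold lower number from compound 2 to compound 3 (0.64 log units; beyond the scatter), which means higher toxicity in this test. The ester also counts when this methyl is present, since hydrogen in place of methyl on the saturated chain carbon bound to an oxygen next to a carbonyl group gives an at least 6.3-fold lower number from compound 1 to compound 3 (0.80 log units; beyond the scatter). Compound 1 stands at a limit and not at a number, so that second step marks only a minimum size: the limit of > 100000 nM in this assay, at which 1 of the 3 values shown sits.

Going by these compounds, whether this position responds to methyl alone or also to a chlorine atom or an ethyl group remains open. So does the effect of a carboxylic acid in place of the ester.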